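Swapping nitro for bromo on the phenyl ring

A few compounds are considered here, and "the series" means these few. Any claim that something is new, unique, unknown or untested is made for them only; others in the source may bear on it.

Compound 1: `O=Cc1c(-c2ccc([N+](=O)[O-])cc2)nc2sc(Cc3ccccc3)nn12` gives 45700 nM
Compound 2: `O=[N+]([O-])c1ccc(-c2nc3sc(Cc4ccccc4)nn3c2Br)cc1` gives 56200 nM

Both compounds were tested in a functional assay on NSCLC cells (Homo sapiens) for inhibition; on this read-out lower numbers stand for stronger inhibition of growth and higher numbers for weaker inhibition of growth. Compound 1 has the lower of the two numbers, but the step of a 1.2-fold higher number from compound 1 to compound 2 (0.09 log units; within the scatter) does not separate them, so compound 1 and compound 2 should be seen as equally active within the scatter.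

Compound 3, `O=Cc1c(-c2ccc(Br)cc2)nc2sc(Cc3ccccc3)nn12`, has not yet been measured. It differs from compound 1 in one place: bromo in place of nitro on an aromatic carbon. Among the measured compounds shown here, the one measured step, from compound 1 to compound 2, changes a different part of the molecule, the formyl on the shared core rather than the nitro on the six-membered carbon ring, so no measured step tests the change that leads to compound 3. What the data do show is that one exchange of a group on these molecules, bromo for formyl, moved the number by a 1.2-fold higher number from compound 1 to compound 2 (0.09 log units; within the scatter), that is, not beyond the scatter.

With no closer guide, compound 3 is expected to stay near compound 1, with a step of a 1.0-fold lower number from compound 1 to compound 3 (0.01 log units; within the scatter), giving an estimated 45000 nM with a range from 15000 nM to 140000 nM.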

Compound 3, concentration for total growth inhibition: 30200 nM
Estimate against measurement, compound 3: 1.5-fold (0.17 log units) above; the range from low to high includes it.
By their numbers in this assay, from the lowest: compounds 3, 1 and 2 (each within the scatter of the next).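

In this assay, bromo in place of nitro on the six-membered carbon ring, para to a large group, gives a 1.5-fold lower number from compound 1 to compound 3 (0.18 log units; within the scatter), so compound 1 and compound 3 count as equally active within the scatter. Among the compounds shown here, this is the first measured test of this position, and it shows that the read-out holds when nitro, with three heavy atoms and two hydrogen-bond acceptors, gives way to bromo, a single heavy atom with no hydrogen-bond acceptor, so in this pair the nitro group is not required for the growth inhibition seen. No measurement shown here offers an explanation for this result.

This single exchange leaves open whether a different kind of group at this position, such as an amine or a carboxylic acid, would move the number beyond the scatter. It also leaves open whether bromo for nitro would give a similar result in compound 2, where bromo rather than formyl sits on the shared core.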